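Sulfamoyl for Ethoxycarbonyl on an Aryl Urea

This account rests on a few compounds, and the source may have more. Where it says the series, first, only, none or still open, it means among the compounds named here.

Compound 1 `CCOC(=O)c1ccc(NC(=O)N2CC2C#N)cc1` sits second highest of the three measured compounds in a functional assay on RPMI-8226 cells (Homo sapiens) for inhibition (a lower number here means a stronger inhibitor, a higher number a weaker inhibitor), where compound 1 gives 3000 nM. Compound 2 `N#CC1CN1C(=O)Nc1ccc(Cl)c(Cl)c1` gives 2700 nM, within the scatter of compound 1. Compound 3 `N#CC1CN1C(=O)NCc1ccccc1` gives 11000 nM, a higher number than compound 1 and beyond the scatter. Compound 4 `N#CC1CN1C(=O)Nc1ccc(S(N)(=O)=O)cc1` has not yet been measured. It differs from compound 1 in one place: sulfamoyl in place of ethoxycarbonyl on an aromatic carbon. Going by the values given here, no measured pair shows this same change, so nothing here tells what it does. The step of a 1.3-fold higher number from compound 1 to compound 4 (0.12 log units; within the scatter) is expected to stay within the scatter, with no clear direction. The estimate for compound 4 in this assay is 4000 nM, with a range from 1500 nM to 12000 nM.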

Compound 4, half-maximal inhibitory concentration: > 38000 nM
Compound 4: no number, only a limit; the forecaster's own chance of this, stated with the estimate: 10%; middle value at least 9.5-fold (0.97 log units) away from the limit.
By their numbers in this assay, from the lowest: compounds 2 and 1 (each within the scatter of the next); then compound 3. At a limit, above all of these: compound 4.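

Sulfamoyl in place of ethoxycarbonyl on an aromatic carbon gives an at least 12-fold higher number from compound 1 to compound 4 (1.10 log units; beyond the scatter), so the group at this position can strongly change the result in this assay. Compound 4 has a limit and not a number, > 38000 nM. The full size of the step therefore stays unknown: the limit of > 38000 nM in this assay, at which 1 of the 4 values shown sits.

Which part of the sulfamoyl group goes with this weaker inhibition remains open. As far as these compounds go, it is also open whether a carboxylic acid, a methyl ester or an amine at this position would stay close to compound 1 or fall with compound 4.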